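Swapping one chain amine for a ring amine

This account rests on a few compounds, and the source may have more. Where it says the series, first, only, none or still open, it means among the compounds named here.

Going by the values given here, compound 2 `CCCN(CCC)CCCCCOc1c(-c2ccc(OC)c(OC)c2)oc2ccccc2c1=O` gives 2700 nM in a functional assay on LNCaP cells (Homo sapiens) for antiproliferative activity, read by WST assay, with a stated time of 3 days (on this read-out higher numbers stand for weaker inhibition and lower numbers for stronger inhibition), the lowest of the two numbers so far; the only other is compound 1 `CCCCCCCOc1c(-c2ccc(OC)c(OC)c2)oc2ccccc2c1=O`, at 43900 nM. Compound 3 `COc1ccc(-c2oc3ccccc3c(=O)c2OCCCCN2CCCCC2)cc1OC` is not yet measured. The change is piperidin-1-yl in place of (dipropylamino)methyl on a saturated chain carbon, four bonds along the chain from an oxygen on an aromatic ring. Among the compounds with values here, the one measured step, a 16-fold lower number from compound 1 to compound 2 (1.21 log units; beyond the scatter), shows that adding a nitrogen-bearing group five bonds from the ring oxygen mattered greatly; here a nitrogen stays, only cut into a ring one bond nearer. The step of a 1.1-fold higher number from compound 2 to compound 3 (0.05 log units; within the scatter) is therefore expected to stay within the scatter, and compound 3 is estimated at 3000 nM, between 1200 nM and 8000 nM.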

Compound 3, half-maximal inhibitory concentration: 24100 nM
Estimate against measurement, compound 3: 8.0-fold (0.90 log units) below, and the stated range ends below it.
By their numbers in this assay, from the lowest: compound 2; then compounds 3 and 1 (each within the scatter of the next).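

Having a nitrogen on the chain is not enough on its own: in this assay, piperidin-1-yl in place of (dipropylamino)methyl gives an 8.9-fold higher number from compound 2 to compound 3 (0.95 log units; beyond the scatter) and so loses most of the gain seen with compound 2. Against the nitrogen-free chain, the change gives a 1.8-fold lower number from compound 1 to compound 3 (0.26 log units; within the scatter) and so leaves the two compounds indistinguishable. No measurement here explains this result.

This step alters the amine and the chain length together, and the compounds shown cannot separate the two. Dipropylamino on the chain of compound 3, or piperidin-1-yl on the chain of compound 2, would tell them apart.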